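Benzylic carbamate replaced by a bare hydroxyl

A few compounds are considered here, and "the series" means these few. Any claim that something is new, unique, unknown or untested is made for them only; others in the source may bear on it.

Compound 3 `CCCC[S+]([O-])c1sc2nc(-c3nccs3)cc(-c3ccc(COC(=O)NCC)cc3)c2c1N` gives 3.4 nM in an assay for inhibition of 15-hydroxyprostaglandin dehydrogenase [NAD(+)] (Homo sapiens), read by fluorescence, with a stated time of 15 min, in the presence of a further agent that is not named here (a lower number here means a stronger inhibitor, a higher number a weaker inhibitor), the lowest of the two numbers shown. Compound 1 `CCCC[S+]([O-])c1sc2nc(-c3nccs3)cc(-c3ccc(COC(=O)CN(C)C)cc3)c2c1N` gives 3.5 nM in this assay, and the step of a 1.0-fold lower number from compound 1 to compound 3 (0.01 log units; within the scatter) lies within the scatter. Compound 2 `CCOC(=O)c1sc2nc(-c3cccs3)cc(-c3ccccc3)c2c1N` reaches only a limit in this assay, > 7500 nM. Compound 4 `CCCC[S+]([O-])c1sc2nc(-c3nccs3)cc(-c3ccc(CCO)cc3)c2c1N` is not yet measured; from compound 3 it differs by hydroxymethyl in place of (ethylcarbamoyl)oxy on a saturated chain carbon bound to an aromatic carbon. Going by the values given here, only the step from compound 1 to compound 3 bears on this position, and that exchange of one carbonyl-bearing group for another left the number unchanged. Among the compounds with values here, the present change removes the carbonyl group altogether, so a move beyond the scatter cannot be excluded, yet the single precedent points to a small step. For compound 4 in this assay a value of 5 nM is expected, from 1.5 nM to 20 nM. The expected step is a 1.5-fold higher number from compound 3 to compound 4 (0.17 log units; within the scatter).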

Compound 4, half-maximal inhibitory concentration: 2.9 nM
Beside the measured number, compound 4's estimate is 1.7-fold (0.24 log units) above it; low and high end bracket the measured number.
By their numbers in this assay, from the lowest: compounds 4, 3 and 1 (each within the scatter of the next). At a limit, above all of these: compound 2.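

In this assay, hydroxymethyl in place of (ethylcarbamoyl)oxy gives a 1.2-fold lower number from compound 3 to compound 4 (0.07 log units; within the scatter), and against the ester of compound 1 it gives a 1.2-fold lower number from compound 1 to compound 4 (0.08 log units; within the scatter). The carbonyl is therefore not required at this position: across compounds 1, 3 and 4, the two carbonyl-bearing groups and the 2-hydroxyethyl end all lie within the scatter of one another. Nothing measured here bears on why the number holds at this position. On these data alone, whether the terminal hydroxyl itself counts remains open; a plain ethyl chain, an amine or a carboxylic acid in its place would test that.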